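This account rests on a few compounds, and the source may have more. Where it says the series, first, only, none or still open, it means among the compounds named here.

Working notes on the series. Within the data shown here, in a functional assay on FM3A cells (Mus musculus) for antiproliferative activity, with a stated time of 48 h (on this read-out higher numbers stand for weaker inhibition and lower numbers for stronger inhibition), compound 1 `C=C(Br)C(=O)Nc1ccc(/C=C/C(=O)c2ccc(Cl)c(Cl)c2)cc1` gives 3200 nM and compound 2 `C=C(Br)C(=O)Nc1ccc(/C=C/C(=O)c2ccc(Br)cc2)cc1` gives 1100 nM, so compound 2 holds the lower of the two numbers so far. Compound 3 `C=C(Br)C(=O)Nc1ccc(/C=C/C(=O)c2ccc(I)cc2)cc1` departs from compound 2 by a single exchange, iodo in place of bromo on an aromatic carbon, para to a large group: iodo in place of bromo on an aromatic carbon. Among the measured compounds shown here, only one measured step bears on this, the modest 2.9-fold lower number from compound 1 to compound 2 (0.46 log units; beyond the scatter), beyond the scatter, with 4-bromophenyl in place of 3,4-dichlorophenyl on a carbonyl carbon. For the measured compounds named here, that step shows that this assay responds to a change in this group, but no measured pair exchanges bromo for iodo, so it gives no direction here. The expected change is small and within the scatter, a 1.1-fold lower number from compound 2 to compound 3 (0.04 log units; within the scatter). For compound 3 the estimated value is 1000 nM, with an expected range of 450 nM to 2500 nM.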

Compound 3, half-maximal inhibitory concentration: 8300 nM
The estimate for compound 3 lay 8.3-fold (0.92 log units) below the measured number; the measured number lies above the stated range.
By their numbers in this assay, from the lowest: compound 2; then compound 1; then compound 3.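

In this assay the halogen at this place is not interchangeable: iodo in place of bromo gives a 7.5-fold higher number from compound 2 to compound 3 (0.88 log units; beyond the scatter), a sharp loss from a single-atom exchange that the earlier pair could not reveal. Against the 3,4-dichlorophenyl group the 4-iodophenyl group also falls behind, with a 2.6-fold higher number from compound 1 to compound 3 (0.41 log units; beyond the scatter), so compound 3 is the weakest of the three, and the 4-bromophenyl group of compound 2 is the best of these aryl groups. Nothing at hand accounts for this sensitivity to the halogen.

From the compounds shown here alone, it remains open whether a lone chloro or fluoro at this place would match bromo or fall away as iodo does. How a methoxy group or an amine would fare there is equally unsettled.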